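A Second Fluorine on the Benzothiazole Ring

The compounds below may be only part of what the source reports. "The series", "measured", "known", "first", "only" and "open" are said of these compounds alone.

Of the compounds shown here, three sharing one core have been tested in a functional assay on SK-OV-3 cells (Homo sapiens) for cytotoxicity, read by sulforhodamine B assay, with a stated time of 48 h; a lower number here means a stronger inhibitor, a higher number a weaker inhibitor. Compound 1 `O=c1cc(-c2ccccc2)oc2cc(OCCCCNc3nc4ccccc4s3)cc(O)c12` gives 48.5 ug/mL. Compound 2 `O=c1cc(-c2ccccc2)oc2cc(OCCCCNc3nc4ccc(Br)cc4s3)cc(O)c12`, carrying bromo in place of hydrogen on an aromatic carbon, gives 35.1 ug/mL. Compound 3 `O=c1cc(-c2ccccc2)oc2cc(OCCCCNc3nc4ccc(F)cc4s3)cc(O)c12`, carrying fluoro at that same place, gives 33.7 ug/mL. For the measured compounds named here, compound 3 has the lowest number of the three, yet the steps of a 1.4-fold lower number from compound 1 to compound 3 (0.16 log units; within the scatter) and a 1.0-fold lower number from compound 2 to compound 3 (0.02 log units; within the scatter) both lie within the scatter, so no compound can be called stronger than another on these numbers.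

Compound 4 `O=c1cc(-c2ccccc2)oc2cc(OCCCCNc3nc4c(F)cc(F)cc4s3)cc(O)c12` differs from compound 3 by fluoro in place of hydrogen on an aromatic carbon. Going by the values given here, the only steps that bear on adding a halogen to this ring are a 1.4-fold lower number from compound 1 to compound 2 (0.14 log units; within the scatter) and a 1.4-fold lower number from compound 1 to compound 3 (0.16 log units; within the scatter), and neither left the scatter. The step in this assay from compound 3 to compound 4 is therefore expected to be small, a 1.1-fold lower number from compound 3 to compound 4 (0.05 log units; within the scatter), without a clear direction. Compound 4 is estimated to give 30 ug/mL, with a likely range from 15 ug/mL to 60 ug/mL.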

Compound 4, half-maximal inhibitory concentration: 36.8 ug/mL
Estimate against measurement, compound 4: 1.2-fold (0.09 log units) below; low and high end bracket the measured number.
By their numbers in this assay, from the lowest: compounds 3, 2, 4 and 1 (each within the scatter of the next).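

A fluoro at this second place, ortho to a fused ring and meta to the first fluoro, gives a 1.1-fold higher number from compound 3 to compound 4 (0.04 log units; within the scatter) in this assay, so adding to the ring of compound 3 leaves the number within the scatter. The 4,6-difluoro-1,3-benzothiazol-2-yl group also cannot be told apart from the two groups tested earlier: the comparison with 6-bromo-1,3-benzothiazol-2-yl reads a 1.0-fold higher number from compound 2 to compound 4 (0.02 log units; within the scatter) and the one with plain 1,3-benzothiazol-2-yl reads a 1.3-fold lower number from compound 1 to compound 4 (0.12 log units; within the scatter) in the same way. No measurement here explains these numbers.

On these data alone, it remains open whether a group of another kind on this ring, such as an amine or a carboxylic acid, would move the number beyond the scatter. The same question stands for a longer chain in place of the one linking the amine nitrogen to the shared core.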